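The source may report more compounds than this note shows. Statements on the series, on what has been measured and on what is new or still open speak of the compounds shown alone.

Two measured compounds share one core and differ only in the group placed on a saturated chain carbon bound to a sulfur. Compound 1 `Cc1cc(S(=O)(=O)/N=C(\N)N/N=C/C#Cc2ccccc2)c(SCc2ccccc2C)cc1Cl` carries a methyl on an aromatic carbon there, and in a functional assay on MCF7 cells (Homo sapiens) for antiproliferative activity, read by MTT assay, with a stated time of 72 h (a lower number here means a stronger inhibitor, a higher number a weaker inhibitor), compound 1 gives 13000 nM. Compound 2 `Cc1cc(S(=O)(=O)/N=C(\N)N/N=C/C#Cc2ccccc2)c(SCc2ccccc2C(F)(F)F)cc1Cl` carries a trifluoromethyl instead, and in this assay compound 2 gives 14000 nM. Compound 2 stands alongside compound 1: the step of a 1.1-fold higher number from compound 1 to compound 2 (0.03 log units; within the scatter) separates them by nothing beyond the scatter. Compound 3 `Cc1cc(S(=O)(=O)/N=C(\N)N/N=C/C#Cc2ccccc2)c(SCc2cccc3ccccc23)cc1Cl` is not yet measured; it differs from compound 2 by naphthalen-1-yl in place of 2-(trifluoromethyl)phenyl on a saturated chain carbon bound to a sulfur. Among the compounds with values here, no measured step concerns this exchange, and the one known step, a 1.1-fold higher number from compound 1 to compound 2 (0.03 log units; within the scatter), was flat for a different swap, so little movement is expected. The expected step is a 1.2-fold lower number from compound 2 to compound 3 (0.07 log units; within the scatter). Compound 3 is therefore estimated at 12000 nM, with a likely range from 5000 nM to 30000 nM.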

Compound 3, half-maximal inhibitory concentration: 22000 nM
The estimate for compound 3 lay 1.8-fold (0.26 log units) below the measured number; the measured number falls inside the stated range.
By their numbers in this assay, from the lowest: compounds 1, 2 and 3 (each within the scatter of the next).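

In this assay, placing naphthalen-1-yl on a saturated chain carbon bound to a sulfur gives a 1.6-fold higher number from compound 2 to compound 3 (0.20 log units; within the scatter) and a 1.7-fold higher number from compound 1 to compound 3 (0.23 log units; within the scatter), so both steps stay within the scatter. The earlier pair covered only an exchange of methyl for trifluoromethyl on the aromatic ring, whereas these steps replace 2-(trifluoromethyl)phenyl or 2-methylphenyl with a group of 2 six-membered aromatic rings of carbon only, and the three compounds still cannot be told apart. No measurement shown here explains why the numbers stay so close.

All three compounds carry only carbon-ring aromatic groups at this place, so they cannot show how a group of another kind, such as an amine or a carboxylic acid, would read. Nor do they show whether a longer chain between the sulfur and the aromatic ring would move the number beyond the scatter.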